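The source may hold more compounds than are shown below. What is called first, only, known or untested is meant among the compounds shown, and "the series" means these compounds.

In an assay on isolated protein for inhibition of sodium channel protein type 3 subunit alpha (Homo sapiens), read by electrophysiology, with a stated time of 4 min (a lower number here means a stronger inhibitor, a higher number a weaker inhibitor), compound 1 `CC(C)(C)OC(=O)n1cc(-c2ccc(NC(=O)c3ccco3)cc2)nc1N` gives 27000 nM. Compound 2 `CC(C)(C)OC(=O)n1cc(-c2ccc(NC(=O)c3cc4ccccc4[nH]3)cc2)nc1N` carries 1H-indol-2-yl in place of furan-2-yl on a carbonyl carbon, and in this assay compound 2 gives 22000 nM; the step of a 1.2-fold lower number from compound 1 to compound 2 (0.09 log units; within the scatter) is within the scatter. Compound 3 `CNc1nc(-c2cccc(NC(=O)c3ccco3)c2)cn1C(=O)OC(C)(C)C` sits on a different core; the difference between the core of compound 1 and the core of compound 3 is not broken down here. In this assay compound 3 gives only a limit, > 30000 nM, which is the limit of > 30000 nM in this assay, at which 1 of the 3 values shown sits.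

Compound 4 `CNc1nc(-c2cccc(NC(=O)c3cc4ccccc4[nH]3)c2)cn1C(=O)OC(C)(C)C` is not yet measured. For the measured compounds named here, it carries 1H-indol-2-yl in place of furan-2-yl on a carbonyl carbon, the same change as the one from compound 1 to compound 2, now on the core of compound 3. Resting on the step of a 1.2-fold lower number from compound 1 to compound 2 (0.09 log units; within the scatter), which stayed within the scatter, the expected step is a step that the limit leaves unreadable from compound 3 to compound 4, applied to a starting point that is itself a limit. Compound 4 is therefore expected in this assay to give about 35000 nM, with a range from 15000 nM to 90000 nM, and with a considerable chance that again only a limit and no number is reported.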

Compound 4, half-maximal inhibitory concentration: > 30000 nM
Compound 4 ended at the assay's limit; the forecaster's own chance of this, stated with the estimate: 65%; the middle value is on the limit's open side.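

In this assay, compound 3 and compound 4 both give only a limit, so no step can be read for 1H-indol-2-yl in place of furan-2-yl on their core: the limit of > 30000 nM in this assay, at which 2 of the 4 values shown sit.

The compounds shown leave open whether this change does on that core what it does on the core of compound 1.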